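The source may report more compounds than this note shows. Statements on the series, on what has been measured and on what is new or still open speak of the compounds shown alone.

Compound 1 `COc1ccc(C2=C(c3cc(OC)c(OC)c(OC)c3)C(=O)CC2O[SiH2]C(C)(C)C)cc1` gives > 100 ug/mL (a limit)
Compound 2 `COc1cc(C2=C(c3cc(C)c(OC)c(C)c3)C(O)CC2=O)cc(OC)c1OC` gives > 100 ug/mL (a limit)

Both entries come from an ADME assay on PA-1 cells (Homo sapiens) for cytotoxicity, read by MTT assay, with a stated time of 72 h (on this read-out lower numbers stand for stronger inhibition and higher numbers for weaker inhibition), and neither is a number. Among the compounds with values here, the series so far shows only the limit of > 100 ug/mL in this assay, at which 2 of the 2 values shown sit, and nothing finer. Compound 2 at > 100 ug/mL stands on a limit of the assay. Compound 3 `COc1cc(C2=C(c3cc(C)c(OC)c(C)c3)C(OC(C)=O)CC2=O)cc(OC)c1OC` carries acetyl in place of hydrogen on an oxygen on a saturated carbon, hydroxy to acetoxy, counted as acetyl in place of hydrogen on an oxygen on a saturated carbon in full. Within the data shown here, no step so far sizes this change in this assay. So a number no higher from compound 2 to compound 3 (the limit leaves the size open) is expected to stay within the scatter, with no direction. The estimate for compound 3 is 100 ug/mL and readings are expected from 40 ug/mL to 200 ug/mL in most cases.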

Compound 3, half-maximal inhibitory concentration: > 100 ug/mL
Compound 3: only a limit was reported; the forecaster's own chance of this, stated with the estimate: 80%; the middle value lies on the limit itself.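

No step can be read between compound 2 and compound 3 in this assay as both entries are limits: the limit of > 100 ug/mL in this assay, at which 3 of the 3 values shown sit. Whether acetyl in place of hydrogen on an oxygen on a saturated carbon shifts the read-out at all stays open among the compounds shown.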